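The source may report more compounds than this note shows. Statements on the series, on what has been measured and on what is new or still open speak of the compounds shown alone.

Measured so far:
- Compound 1 `COc1ccc(-c2sc(C(=O)O)cc2-c2cc(OC)c(OC)c(OC)c2)cc1` gives 6770 nM
- Compound 2 `COc1ccc(-c2sc(C(=O)O)cc2-c2cc(OC)c(OC)c(OC)c2)cc1[N+](=O)[O-]` gives 37200 nM

In a functional assay on HT-1080 cells (Homo sapiens) for antiproliferative activity, read by MTT assay, with a stated time of 72 h (on this read-out higher numbers stand for weaker inhibition and lower numbers for stronger inhibition), compound 2 stands highest of the two at 37200 nM so far. Compound 3 `COc1ccc(-c2sc(C(=O)O)cc2-c2cc(OC)c(OC)c(OC)c2)cc1OCc1ccccc1` has benzyloxy in place of nitro on an aromatic carbon. Going by the values given here, the only measured step at this place, nitro in place of hydrogen, is a 5.5-fold higher number from compound 1 to compound 2 (0.74 log units; beyond the scatter) and no measured compound carries benzyloxy. A smaller step toward a lower number is therefore expected in this assay with little certainty. The expected step is a 2.5-fold lower number from compound 2 to compound 3 (0.39 log units; beyond the scatter) by this estimate. Compound 3 is estimated at 15000 nM within a range of 4000 nM to 50000 nM on this read-out.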

Compound 3, half-maximal inhibitory concentration: > 100000 nM
Compound 3: no number, only a limit; the forecaster's own chance of this, stated with the estimate: 15%; middle value at least 6.6-fold (0.82 log units) from the limit.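

In this assay, benzyloxy in place of nitro gives an at least 2.6-fold higher number from compound 2 to compound 3 (0.42 log units; beyond the scatter), and benzyloxy in place of hydrogen gives an at least 14-fold higher number from compound 1 to compound 3 (1.16 log units; beyond the scatter). Both groups tried at this position therefore raise the number relative to hydrogen, and the change to benzyloxy does not recover any of the ground lost with nitro. Compound 3 gives only a limit, not a number: the limit of > 100000 nM in this assay, at which 1 of the 3 values shown sits.

As far as these compounds go, how far compound 3 lies past that limit stays open. So does whether an amine or a hydroxyl group at this position would give a number lower than that of compound 1.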